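An Amino Group in Place of Chloro on a Quiet Series

This account rests on a few compounds, and the source may have more. Where it says the series, first, only, none or still open, it means among the compounds named here.

Compound 2, `Nc1nn(C(=O)Nc2ccc(Cc3ccccc3)cc2)c2ccc(Cl)cc12`, carries a chloro group on the shared core. In a functional assay on HOP-92 cells (Homo sapiens) for antiproliferative activity, read by sulforhodamine B assay, with a stated time of 48 h (a lower number here means that less compound is tolerated, a higher number that more compound is tolerated), compound 2 gives a value that is only a limit of the assay, > 100000 nM. Its companion compound 1, `Nc1nn(C(=O)Nc2ccc(Cc3ccccc3)cc2)c2ccccc12`, differs from it only at that carbon, which bears hydrogen instead of chloro. In this assay compound 1 likewise gives only a limit, > 100000 nM. The step that the two limits leave unreadable from compound 1 to compound 2 therefore cannot be read in size or direction, since the limit of > 100000 nM in this assay, at which 2 of the 2 values shown sit, shows both values resting at the same limit. The next compound, compound 3, `Nc1ccc2c(c1)c(N)nn2C(=O)Nc1ccc(Cc2ccccc2)cc1`, differs from compound 2 in one place: amino in place of chloro on an aromatic carbon. Within the data shown here, no measured step bears directly on exchanging chloro for amino at this position, and the only step on record, from hydrogen to chloro, left both compounds at the limit. For compound 3 in this assay the expectation is most likely another limit rather than a readable step, so the step of a number no higher from compound 2 to compound 3 (the limit leaves the size open) is estimated to be small. Compound 3 is expected to give about 100000 nM, with a range from 30000 nM to 300000 nM.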

Compound 3, concentration lethal to 50% of the cells: 57400 nM
For compound 3 the middle estimate is 1.7-fold (0.24 log units) above the measured one, within the range that was stated.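

In this assay, among these compounds, compound 3 is the first compound here to give a number rather than a limit, so a change at this aromatic carbon can now be given at least a minimum size. Amino in place of chloro gives an at least 1.7-fold lower number from compound 2 to compound 3 (0.24 log units; that floor lies within the scatter), and amino in place of hydrogen gives an at least 1.7-fold lower number from compound 1 to compound 3 (0.24 log units; that floor lies within the scatter). Each figure is a floor rather than a size, because the starting end of each step is a limit and not a number: the limit of > 100000 nM in this assay, at which 2 of the 3 values shown sit.

The compounds shown leave open how large these two steps really are, since the true step could stay within the scatter or go well beyond it. They also leave open whether amino is special at this aromatic carbon or whether another group there, such as a hydroxyl, a methoxy or a dimethylamino group, would also give a readable number in this assay.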